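Methyl for acetyl on a triazene: half-life expectation

This account rests on a few compounds, and the source may have more. Where it says the series, first, only, none or still open, it means among the compounds named here.

Measured compounds:
Compound 1, `Cc1ccc(/N=N/N(C)C(=O)CCc2ccc(O)cc2)cc1`, in a physicochemical assay for pharmacokinetics, read by HPLC, in phosphate buffer, at pH 7.4 (on this read-out higher numbers stand for a longer-lived compound and lower numbers for a shorter-lived compound), compound 1 gives 101 h.
Compound 2, `CC(=O)c1ccc(/N=N/N(C)C(=O)NCCSc2ccc(O)cc2)cc1`, in this assay compound 2 gives > 240 h, which is a limit of the assay and not a number.

Compound 2 therefore stands only at the top of the scale shown, with no exact figure: its value is the limit described by the limit of > 240 h in this assay, at which 1 of the 2 values shown sits. Among the compounds with values here, compound 1, which carries a different linker and a methyl on its aryl ring, sits at a measured half-life well below that limit; no step between compound 1 and compound 2 is computed, so their two values show only that much.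

Compound 3, `Cc1ccc(/N=N/N(C)C(=O)NCCSc2ccc(O)cc2)cc1`, keeps the whole linker of compound 2 and changes one place: methyl in place of acetyl on an aromatic carbon. With compound 2 known only as a limit, the size of the step cannot be read from any measured pair. Compound 3 is expected to give 120 h in this assay, with a range from 40 h to 300 h. The estimated step of an at least 2.0-fold lower number from compound 2 to compound 3 (0.30 log units; that floor lies within the scatter) is expected to point downward, beyond the scatter.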

Compound 3, half-life: > 240 h
Compound 3 was reported as a limit (the forecaster's own chance of this, stated with the estimate: 25%); at least 2.0-fold (0.30 log units) between middle value and limit.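

Compound 3, like compound 2, is reported in this assay only as a limit and not as a number, so no step between compound 2 and compound 3 can be read: the limit of > 240 h in this assay, at which 2 of the 3 values shown sit.

The compounds shown leave open what the actual half-lives of compound 2 and compound 3 are, and whether methyl in place of acetyl on an aromatic carbon changes the half-life at all.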